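Fluoro in Place of Hydrogen: Expected Cytotoxicity of Compound 4

The compounds below may be only part of what the source reports. "The series", "measured", "known", "first", "only" and "open" are said of these compounds alone.

Compound 1 `CCNCC1CCN(c2c(F)cc3c(=O)c(C(=O)O)cn(NC)c3c2F)C1` and compound 2 `CCNCC1CCN(c2cc3c(cc2F)c(=O)c(C(=O)O)cn3NC)C1` share one core; compound 3 `O=C(O)c1cn(C2CC2)c2cc(N3CCCC3)c(F)cc2c1=O` and compound 4 `O=C(O)c1cn(C2CC2)c2c(F)c(N3CCCC3)c(F)cc2c1=O` share another, and the difference between the two cores is not broken down here. In a functional assay on V79 cells (Cricetulus griseus) for cytotoxicity, read by colony formation (a higher number here means a weaker inhibitor, a lower number a stronger inhibitor), compound 1 reaches only the assay limit, > 500 ug/mL. Compound 2 likewise stops at the limit of this assay, > 500 ug/mL. In this assay compound 3 gives 38 ug/mL. The change fluoro in place of hydrogen on an aromatic carbon gave a step that the two limits leave unreadable from compound 2 to compound 1, so its size cannot be read, as the limit of > 500 ug/mL in this assay, at which 2 of the 3 values shown sit, shows. The change fluoro in place of hydrogen on an aromatic carbon is the same kind of change, but here the place is ortho to a pyrrolidin-1-yl group rather than ortho to a 3-((ethylamino)methyl)pyrrolidin-1-yl group. With the measured step unreadable, only a small step is expected, a 1.3-fold lower number from compound 3 to compound 4 (0.10 log units; within the scatter). Compound 4 is therefore estimated at 30 ug/mL, between 12 ug/mL and 100 ug/mL.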

Compound 4, half-maximal inhibitory concentration: 120 ug/mL
The estimate for compound 4 lay 4.0-fold (0.60 log units) below the measured number; measured number outside the range, above it.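

On the core of compound 3, fluoro in place of hydrogen, ortho to a pyrrolidin-1-yl group, gave a 3.2-fold higher number from compound 3 to compound 4 (0.50 log units; beyond the scatter) in this assay, so on this core the change weakened inhibition beyond the usual scatter. The same change from compound 2 to compound 1 cannot be read, and whether the step carries from one core to the other remains unshown, since both of those compounds stand at a limit of the assay: the limit of > 500 ug/mL in this assay, at which 2 of the 4 values shown sit. One readable step on one core gives no rule for the series and no size for the other core.

The compounds shown leave open whether the step keeps its size with a piperazin-1-yl group in place of the pyrrolidin-1-yl group. They also leave open whether chloro or methoxy on that same aromatic carbon would give a step like that of fluoro.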